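Cyclopropyl to ethoxy on the fused triazole core

The source may report more compounds than this note shows. Statements on the series, on what has been measured and on what is new or still open speak of the compounds shown alone.

Measured compounds:
compound 1, `CCc1nc2nc(C)cc(Nc3cccc(Cl)c3)n2n1`, 125 mL.min-1.g-1
compound 2, `Cc1cc(Nc2ccc(C(F)(F)F)cc2)n2nc(C3CC3)nc2n1`, 8.6 mL.min-1.g-1
compound 3, `Cc1cc(Nc2ccc(Cl)cc2)n2nc(C(C)C)nc2n1`, 158 mL.min-1.g-1

In an in vitro ADME assay on microsomes from liver (Mus musculus) for metabolic stability (on this read-out higher numbers stand for fast clearance and lower numbers for slow clearance), compound 2 stands lowest of the three numbers; compound 1 and compound 3 both sit well beyond the scatter above it. For the measured compounds named here, no pair among the measured compounds differs in a single place, so no step has been measured. Compound 4, `CCOc1nc2nc(C)cc(Nc3ccc(C(F)(F)F)cc3)n2n1`, follows from compound 2 by the change (ethoxy in place of cyclopropyl on an aromatic carbon). The anilide part is kept from compound 2. Going by the values given here, with no measured step to lean on, the expected step is a 3.5-fold higher number from compound 2 to compound 4 (0.54 log units; beyond the scatter), upward, though its size is uncertain; the estimate for compound 4 in this assay is 30 mL.min-1.g-1, within 8 mL.min-1.g-1 to 110 mL.min-1.g-1.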

Compound 4, intrinsic clearance in microsomes: 14.4 mL.min-1.g-1
Estimate against measurement, compound 4: 2.1-fold (0.32 log units) above; measured number inside the range.
By their numbers in this assay, from the lowest: compounds 2 and 4 (each within the scatter of the next); then compounds 1 and 3 (each within the scatter of the next).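

In this assay, for the compounds shown here, ethoxy in place of cyclopropyl on the aromatic carbon between two ring nitrogen atoms gives a 1.7-fold higher number from compound 2 to compound 4 (0.22 log units; within the scatter), the first step that changes only one place. At this position, with the rest of the structure kept, replacing the three-membered carbon ring with an open chain carrying a hydrogen-bond acceptor leaves clearance within the scatter. Nothing available points to a cause for this result. Still open, as far as these compounds go, is how an amine or a longer chain such as butoxy would behave at this position, and whether ethoxy in place of cyclopropyl gives a similar step when chlorine replaces trifluoromethyl on the aniline ring.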